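Methoxy removal on the aryl arm of compound 3

The source may report more compounds than this note shows. Statements on the series, on what has been measured and on what is new or still open speak of the compounds shown alone.

Three close analogues of one core carry the same chlorobenzyl arm and differ only in the group on the second aryl ring. In a functional assay on L1210 cells (Mus musculus) for cytotoxicity, with a stated time of 48 h (a higher number here means a weaker inhibitor, a lower number a stronger inhibitor), compound 1 `Clc1ccc(Cc2nn3c(Br)c(-c4ccc(Cl)cc4)nc3s2)cc1` sits at the limit > 250000 nM, which is a limit of the assay and not a number. Compound 2 `Clc1ccc(Cc2nn3c(Br)c(-c4ccc(Br)cc4)nc3s2)cc1` likewise sits at the limit > 250000 nM, again a limit and not a number. Among the measured compounds shown here, compound 3 `COc1ccc(-c2nc3sc(Cc4ccc(Cl)cc4)nn3c2Br)cc1` is the only one with a number, giving 63000 nM in this assay, so it stands as the sole measured point of the set. The steps of an at least 3.9-fold lower number from compound 1 to compound 3 (0.59 log units; beyond the scatter) and an at least 3.9-fold lower number from compound 2 to compound 3 (0.59 log units; beyond the scatter) are both at least modest and point the same way, from a halogen to methoxy (the limit of > 250000 nM in this assay, at which 2 of the 3 values shown sit).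

Compound 4 `Clc1ccc(Cc2nn3c(Br)c(-c4ccccc4)nc3s2)cc1` is obtained from compound 3 by hydrogen in place of methoxy on an aromatic carbon, that is, 4-methoxyphenyl to phenyl. For the measured compounds named here, no measured pair shows this exact change; the two halogen-to-methoxy steps are the only bearing evidence, and they show that loss of methoxy toward another substituent costs at least a modest step. Taking methoxy out altogether is therefore expected to move the number upward, in this assay, by a 2.9-fold higher number from compound 3 to compound 4 (0.46 log units; beyond the scatter), with a fair chance of falling back to the limit. Compound 4 is estimated at 180000 nM, within 50000 nM to 400000 nM.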

Compound 4, half-maximal inhibitory concentration: > 250000 nM
Compound 4 ended at the assay's limit; the forecaster's own chance of this, stated with the estimate: 50%; at least 1.3-fold (0.14 log units) between middle value and limit.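

In this assay, the direct removal of methoxy from the aromatic carbon para to a large group gives an at least 3.9-fold higher number from compound 3 to compound 4 (0.59 log units; beyond the scatter), so the earlier comparison of methoxy with chloro and bromo now extends to 4-methoxyphenyl against phenyl. Among the four compounds shown, methoxy is the only group at this position that comes with a number, and hydrogen falls on the same side as the two halogens, so no halogen is needed for the loss of a measurable value. The steps among compound 1, compound 2 and compound 4 cannot be read, since each of these compounds carries a limit and not a number: the limit of > 250000 nM in this assay, at which 3 of the 4 values shown sit.

As far as these compounds go, the order of hydrogen, chloro and bromo at this position therefore stays open, as does any difference between them in this assay. Also open, from the compounds shown here alone, is whether the effect belongs to methoxy alone or extends to other groups on this carbon, such as ethoxy, hydroxy or an amine, and whether any of them would give a lower number than compound 3 with 63000 nM.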